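This account rests on a few compounds, and the source may have more. Where it says the series, first, only, none or still open, it means among the compounds named here.

The shared core carries a primary amine and an oxygen on the aromatic ring, and the three compounds differ only in the chain on that oxygen. Compound 1 `COCC(C)Oc1cccc2ccc(N)nc12` bears a 1-(methoxymethyl)ethyl group there, and in an assay on cells with melanin-concentrating hormone receptor 1 (Homo sapiens) as the target, read by radioligand binding (on this read-out higher numbers stand for weaker inhibition and lower numbers for stronger inhibition), compound 1 gives 606 nM. Compound 2 `CC(C)OCCOc1cccc2ccc(N)nc12` bears a 2-isopropoxyethyl group in its place. In this assay compound 2 gives > 2000 nM, which is a limit of the assay and not a number. The step of an at least 3.3-fold higher number from compound 1 to compound 2 (0.51 log units; beyond the scatter) is open-ended at its upper side because the limit of > 2000 nM in this assay, at which 1 of the 2 values shown sits, sets what the step can show. On the numbers shown, compound 2 therefore stands at the weak end of the pair, known only by a limit.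

Compound 3 `CC(C)=CCOc1cccc2ccc(N)nc12` differs from compound 2 by 2-methylprop-1-en-1-yl in place of isopropoxymethyl on a saturated chain carbon bound to an oxygen on an aromatic ring. Within the data shown here, the one measured step that bears on this position, an at least 3.3-fold higher number from compound 1 to compound 2 (0.51 log units; beyond the scatter), shows that exchanging the chain on this oxygen can move the number beyond the scatter, but it gives no direction for a chain that carries no acceptor. Compound 3 is expected to come in at 1500 nM, within a range from 300 nM to 6000 nM. The expected step of an at least 1.3-fold lower number from compound 2 to compound 3 (0.12 log units; that floor lies within the scatter) is thus uncertain in size, and the assay may again report only a limit for compound 3.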

Compound 3, half-maximal inhibitory concentration: > 2000 nM
Compound 3 was reported as a limit; the forecaster's own chance of this, stated with the estimate: 35%; middle value at least 1.3-fold (0.12 log units) away from the limit.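

In this assay compound 3 gives > 2000 nM, which is a limit of the assay and not a number. With 3-methylbut-2-en-1-yl in place of 1-(methoxymethyl)ethyl on the oxygen, the read-out shows an at least 3.3-fold higher number from compound 1 to compound 3 (0.51 log units; beyond the scatter), so a chain with a double bond and no hydrogen-bond acceptor also gives up the measurable value of compound 1, just as the ether chain 2-isopropoxyethyl did. Taking out the isopropoxymethyl group, with its one acceptor, thus brings no readable number back at this position, yet compound 2 and compound 3 cannot be ordered against each other, and the step between them cannot be read, because both sit at the same limit: the limit of > 2000 nM in this assay, at which 2 of the 3 values shown sit.

The compounds shown leave open how far compound 2 and compound 3 lie past that limit, and so whether the two chains differ at all in this assay. They also leave open whether a chain ending in a dimethylamino group or a carboxylic acid on this oxygen, or a longer chain such as 3-methoxypropyl, would return a measurable value, and on which side of compound 1 it would fall.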